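The compounds below may be only part of what the source reports. "The series", "measured", "known", "first", "only" and "open" are said of these compounds alone.

In a functional assay on HL-60 cells (Homo sapiens) for cytotoxicity, read by MTT assay, with a stated time of 3 days (a higher number here means a weaker inhibitor, a lower number a stronger inhibitor), three compounds that share one core and differ only in the amine group attached to it have been measured. Compound 1 `CNc1nc(SCc2nc3ccccc3[nH]2)nc(-c2ccccc2)c1C#N` gives 6.57 nM, compound 2 `N#Cc1c(Nc2nccs2)nc(SCc2nc3ccccc3[nH]2)nc1-c1ccccc1` gives 11.9 nM, and compound 3 `N#Cc1c(-c2ccccc2)nc(SCc2nc3ccccc3[nH]2)nc1N1CCNCC1` gives 4 nM. Compound 3 stands at the low end of these numbers, but it is clearly separated only from compound 2, with a 3.0-fold lower number from compound 2 to compound 3 (0.47 log units; beyond the scatter). By contrast, a 1.6-fold lower number from compound 1 to compound 3 (0.22 log units; within the scatter), and a 1.8-fold higher number from compound 1 to compound 2 (0.26 log units; within the scatter).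

Compound 4 `CN1CCN(c2nc(SCc3nc4ccccc4[nH]3)nc(-c3ccccc3)c2C#N)CC1` changes piperazin-1-yl to 4-methylpiperazin-1-yl, with methyl in place of hydrogen on an amine nitrogen in a ring. Among the measured compounds shown here, no measured step shows this exact change, so the closest evidence is the three swaps of the whole amine group. The largest of these, a 3.0-fold lower number from compound 2 to compound 3 (0.47 log units; beyond the scatter), is only modest. Adding one methyl alters less of the structure than any of those swaps, so no step beyond the scatter is expected, and these data favour no clear direction. The expected step is a 1.3-fold higher number from compound 3 to compound 4 (0.10 log units; within the scatter). Compound 4 is estimated at 5 nM, with an expected range from 2 nM to 12 nM.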

Compound 4, half-maximal inhibitory concentration: 2.8 nM
Compound 4: the middle estimate sits 1.8-fold (0.25 log units) above what was measured; the measured number falls inside the stated range.
By their numbers in this assay, from the lowest: compounds 4, 3, 1 and 2 (each within the scatter of the next, the first and the last beyond it).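

In this assay the piperazin-1-yl nitrogen carries a methyl in place of hydrogen with no change that can be told from scatter, as a 1.4-fold lower number from compound 3 to compound 4 (0.15 log units; within the scatter) shows, so this amine nitrogen in a ring accepts one added carbon without a readable loss or gain. The new compound also keeps the modest separation from the thiazolyl amine seen with compound 3, with a 4.3-fold lower number from compound 2 to compound 4 (0.63 log units; beyond the scatter) here, and it adds a separation from the methylamino compound that compound 3 did not show, with a 2.3-fold lower number from compound 1 to compound 4 (0.37 log units; beyond the scatter) in this case, although compound 3 and compound 4 remain within the scatter of each other. No measurement shown here explains these numbers.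

A single methyl is the only substituent shown on this nitrogen, so it remains open whether an ethyl, a benzyl or an acetyl group there would leave the number in the same range. Going by these compounds, it is also open how far this finding carries to a ring amine with a different second ring atom, such as morpholin-4-yl, or to any other cell line.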